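Methoxy for ethynyl on the carbinol side chain

The compounds below may be only part of what the source reports. "The series", "measured", "known", "first", "only" and "open" are said of these compounds alone.

Compound 1 `C#CCC(O)(c1ccc(N2CCN(S(=O)(=O)c3ccc(N)nc3)C[C@@H]2C#CC)cc1)C(F)(F)F` gives 130 nM in an assay on cells (Hepatocyte) for inhibition of glucokinase regulatory protein (Mus musculus), with stated times of 20 min and 40 min (a lower number here means that less compound is needed, a higher number that more compound is needed for the effect), the lower of the two numbers recorded so far. Compound 2 `CC#C[C@H]1CN(S(=O)(=O)c2ccc(N)nc2)CCN1c1ccc(C(C)(O)C(F)(F)F)nc1` gives 1450 nM in this assay, a weaker result that lies beyond the scatter. Compound 3 `CC#C[C@H]1CN(S(=O)(=O)c2ccc(N)nc2)CCN1c1ccc(C(O)(COC)C(F)(F)F)cc1` differs from compound 1 by methoxy in place of ethynyl on a saturated chain carbon, two bonds along the chain from an aromatic carbon and an oxygen on a saturated carbon. Among the compounds with values here, no measured pair shows this change, so its effect can only be expected: a small shift, most likely toward a higher number or none beyond the scatter. For compound 3 the expected value is 200 nM, in the range 70 nM to 600 nM, the estimated step of a 1.5-fold higher number from compound 1 to compound 3 (0.19 log units; within the scatter) being modest.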

Compound 3, half-maximal effective concentration: 202 nM
Compound 3: middle estimate off by 1.0-fold (0.00 log units), on the low side, within the range that was stated.
By their numbers in this assay, from the lowest: compounds 1 and 3 (each within the scatter of the next); then compound 2.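

On the saturated chain carbon, two bonds along the chain from an aromatic carbon and an oxygen on a saturated carbon, methoxy in place of ethynyl gives a 1.6-fold higher number from compound 1 to compound 3 (0.19 log units; within the scatter) in this assay and the two compounds cannot be told apart. This position therefore accepts propargyl to methoxymethyl, which adds one hydrogen-bond acceptor, with the result staying within the scatter. No measurement bears on the reason for this.

Going by these compounds, whether an amine, a carboxylic acid or a longer chain on this carbon would also stay within the scatter of compound 1 remains open.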